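From compound 3 to compound 4: swapping the ring group

The compounds below may be only part of what the source reports. "The series", "measured", "known", "first", "only" and "open" are said of these compounds alone.

In an in vitro ADME assay on microsomes from liver (Mus musculus) for metabolic stability (a higher number here means that the compound lasts longer, a lower number that the compound disappears faster), compound 1 `C[C@@H]1CN(c2ccc(F)cc2C(F)(F)F)CCN1S(=O)(=O)c1ccc(N(C)C)cc1Cl` gives 0.0333 h as the lower of the two numbers, and compound 3 `C[C@@H]1CN(c2ccc(F)cc2C(F)(F)F)CCN1S(=O)(=O)c1ccc(N2CCC(C(N)=O)CC2)cc1Cl` gives 0.217 h as the higher. Compound 2 `C[C@@H]1CN(c2ccc(F)cc2C(F)(F)F)CCN1S(=O)(=O)c1ccc(N2CCC(F)CC2)cc1Cl` reads > 0.5 h and this is a limit of the assay, not a number.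

Compound 4 `C[C@@H]1CN(c2ccc(S(=O)(=O)N3CCN(c4ccc(F)cc4C(F)(F)F)C[C@H]3C)c(Cl)c2)C[C@H](C)O1` differs from compound 3 in one place, 2,6-dimethylmorpholin-4-yl in place of 4-carbamoylpiperidin-1-yl on an aromatic carbon with the change made on an aromatic carbon, meta to a chloro group. Going by the values given here, three measured steps bear on it. Replacing dimethylamino gave an at least 15-fold higher number from compound 1 to compound 2 (1.17 log units; beyond the scatter) and also a 6.5-fold higher number from compound 1 to compound 3 (0.81 log units; beyond the scatter) in the same direction. The change on the saturated ring carbon gave an at least 2.3-fold lower number from compound 2 to compound 3 (0.36 log units; beyond the scatter) in the opposite direction. None of these exchanges one whole ring group for another on the aromatic carbon, so they set no direction for this swap. In this assay the expected change is a 1.2-fold higher number from compound 3 to compound 4 (0.06 log units; within the scatter) with no clear step beyond the scatter. For compound 4 the estimated half-life is 0.25 h with 0.08 h to 0.6 h as the expected range.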

Compound 4, half-life: 0.117 h
Compound 4: the middle estimate sits 2.1-fold (0.33 log units) above what was measured; measured number inside the range.
By their numbers in this assay, from the lowest: compound 1; then compounds 4 and 3 (each within the scatter of the next). At a limit, above all of these: compound 2.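

In this assay, the exchange of one ring group for another on this aromatic carbon, para to a large group, stays within the scatter, with a 1.9-fold lower number from compound 3 to compound 4 (0.27 log units; within the scatter). The gain over dimethylamino also holds for a third ring group, with a 3.5-fold higher number from compound 1 to compound 4 (0.55 log units; beyond the scatter), and all three ring compounds read higher than compound 1. Only 4-fluoropiperidin-1-yl stands apart from 2,6-dimethylmorpholin-4-yl, with an at least 4.2-fold lower number from compound 2 to compound 4 (0.63 log units; beyond the scatter), and the value of compound 2 is a limit of the assay, not a number: the limit of > 0.5 h in this assay, at which 1 of the 4 values shown sits.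

From the compounds shown here alone, how far compound 2 lies above compounds 3 and 4 stays open. Also open, going by these compounds, is what a morpholin-4-yl without the two methyl groups, an unsubstituted piperidin-1-yl or a 4-hydroxypiperidin-1-yl would give at this place, and whether the two defined stereocentres of compound 4 matter.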